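Removing a Chloro Group from a Tetraacetate Core

This account rests on a few compounds, and the source may have more. Where it says the series, first, only, none or still open, it means among the compounds named here.

Compound 1 `CC(=O)Oc1cc(OC(C)=O)c2c(OC(C)=O)cc(C)c(Cl)c2c1OC(C)=O` was tested in a functional assay on DU-145 cells (Homo sapiens) for cytotoxicity, read by XTT assay, with a stated time of 24 h (on this read-out lower numbers stand for stronger inhibition and higher numbers for weaker inhibition), where compound 1 gives 59600 nM. Two compounds with a different core were also measured in this assay: compound 3 `COc1cc(C)c(Cl)c2c1C(=O)C=CC2=O` gives 26600 nM, and compound 2 `COc1cc(C)cc2c1C(=O)C=CC2=O` gives 30700 nM. The difference between the two cores is not broken down here. Compound 2 arises from compound 3 by hydrogen in place of chloro on an aromatic carbon, and this step made a 1.2-fold higher number from compound 3 to compound 2 (0.06 log units; within the scatter). Compound 4 `CC(=O)Oc1cc(OC(C)=O)c2c(OC(C)=O)cc(C)cc2c1OC(C)=O` arises from compound 1 by hydrogen in place of chloro on an aromatic carbon; the surroundings differ, since the site is para to an acetoxy group in compound 1 rather than para to a methoxy group in compound 3, so this is the same kind of change, not the same one. Because the earlier step gave a 1.2-fold higher number from compound 3 to compound 2 (0.06 log units; within the scatter), the step from compound 1 to compound 4 is expected to be a 1.1-fold higher number from compound 1 to compound 4 (0.04 log units; within the scatter). Compound 4 is therefore estimated at 65000 nM, with an expected range from 30000 nM to 140000 nM.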

Compound 4, half-maximal inhibitory concentration: 64600 nM
Compound 4: middle estimate off by 1.0-fold (0.00 log units), on the high side, and the stated range covers the measured number.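

On the core of compound 1, hydrogen in place of chloro in this assay gives a 1.1-fold higher number from compound 1 to compound 4 (0.03 log units; within the scatter), so swapping these two atoms makes no readable difference here. The same change comes out at much the same small size on both cores: the same change on two cores in this assay, a 1.2-fold higher number (0.06 log units; within the scatter) from compound 3 to compound 2 and a 1.1-fold higher number (0.03 log units; within the scatter) from compound 1 to compound 4, 1.1-fold (0.03 log units) apart, within the scatter of two such steps. This shows that the swap carried over between these two cores in this assay, but it gives no reason for the result and says nothing about other cores or other read-outs.

The compounds shown carry only chloro or hydrogen at this site, so it remains open whether an amine, a carboxylic acid or a longer chain there would shift the number. Among these compounds, no single-place step links the two cores, so they cannot be compared directly.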